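The source may hold more compounds than are shown below. What is called first, only, known or untested is meant among the compounds shown, and "the series" means these compounds.

Compound 1 `CCCCCCCN1CCC(C(=O)Nc2cc(Cl)c(N)cc2OC)CC1` carries hexyl on a saturated chain carbon bound to an amine nitrogen in a ring. In a functional assay on the whole organism for antagonist activity, with Mus musculus as the target (a higher number here means that more compound is needed for the effect, a lower number that less compound is needed), compound 1 gives only a limit, > 10 mg/kg. Compound 2 `CCCCN1CCC(C(=O)Nc2cc(Cl)c(N)cc2OC)CC1` is the chain-shortened partner; in this assay compound 2 likewise gives only a limit, > 10 mg/kg. Compound 3 `COc1cc(N)c(Cl)cc1NC(=O)C1CCN(CC2CCCC2)CC1` carries cyclopentyl in the same place; in this assay compound 3 also gives only a limit, > 10 mg/kg. Compound 1 therefore stands nowhere readable on the numbers: every value shown sits at the limit of > 10 mg/kg in this assay, at which 3 of the 3 values shown sit, and the steps a step that the two limits leave unreadable from compound 1 to compound 2, a step that the two limits leave unreadable from compound 1 to compound 3 and a step that the two limits leave unreadable from compound 2 to compound 3 cannot be sized or given a direction.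

Compound 4 `COc1cc(N)c(Cl)cc1NC(=O)C1CCN(CC2CCCCCC2)CC1` differs from compound 1 as follows: cycloheptyl in place of hexyl on a saturated chain carbon bound to an amine nitrogen in a ring. The closest measured precedent is the step from compound 1 to compound 3, a ring entering where an open chain leaves on a saturated chain carbon bound to an amine nitrogen in a ring, but that step is unreadable. No step beyond the scatter can be expected in this assay in either direction on this evidence; the most probable outcome is that compound 4 again reaches only the limit. Compound 4 is estimated at 15 mg/kg, with a range of 7 mg/kg to 40 mg/kg, which corresponds to an expected step that the limit leaves unreadable from compound 1 to compound 4.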

Compound 4, dose for half-maximal effect: > 10 mg/kg
Compound 4 gave a limit, no number; the forecaster's own chance of this, stated with the estimate: 75%; the middle value does not contradict the limit.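

In this assay compound 4 gives > 10 mg/kg, which is a limit and not a number. No step between compound 4 and compound 1, compound 2 or compound 3 can be read, and all four share one value: the limit of > 10 mg/kg in this assay, at which 4 of the 4 values shown sit.

The compounds shown leave open whether changing the group on a saturated chain carbon bound to an amine nitrogen in a ring shifts the dose in this assay at all, and in which direction.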